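Removing a Trifluoromethyl Group from Two Related Calcium Channel Inhibitors

This account rests on a few compounds, and the source may have more. Where it says the series, first, only, none or still open, it means among the compounds named here.

Measured compounds:
compound 1, `CN(Cc1ccc(OCCCNC(=N)N)cc1)c1nc2ccc(Oc3ccc(C(F)(F)F)cc3)cc2s1`, 185000 nM
compound 2, `CN(Cc1ccc(OCCCNC(=N)N)cc1)c1nc2ccc(Oc3ccccc3)cc2s1`, 113000 nM
compound 3, `NCCCOc1ccc(CNc2nc3ccc(Oc4cccc(C(F)(F)F)c4)cc3s2)cc1`, 144000 nM

Of the compounds shown here, three have been measured in an assay on SH-SY5Y cells for inhibition of Voltage-dependent N-type calcium channel subunit alpha-1B (Homo sapiens), read by FLIPR and calcium flux, with stated times of 600 s and 300 s, in the presence of a further agent that is not named here; a higher number here means a weaker inhibitor, a lower number a stronger inhibitor. Compound 1 gives 185000 nM, compound 2 gives 113000 nM, and compound 3 gives 144000 nM. All three values lie within the scatter of one another, so no order among them can be claimed.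

Compound 1 and compound 2 differ in one place: hydrogen in place of trifluoromethyl on an aromatic carbon. This change gave a 1.6-fold lower number from compound 1 to compound 2 (0.21 log units; within the scatter), a step that the scatter of the assay does not separate from no change at all.

Compound 4, `NCCCOc1ccc(CNc2nc3ccc(Oc4ccccc4)cc3s2)cc1`, has not yet been measured in this assay. It differs from compound 3 in one place: hydrogen in place of trifluoromethyl on an aromatic carbon. Compound 3 and compound 1 carry different cores, and the difference between the two cores is not broken down here. The change from compound 3 to compound 4 is the same kind of change as that from compound 1 to compound 2, but not the same: in compound 1 the trifluoromethyl sits para to a large group, whereas in compound 3 it sits meta to a large group.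

Given that the earlier step read a 1.6-fold lower number from compound 1 to compound 2 (0.21 log units; within the scatter), the step from compound 3 to compound 4 is expected to be of similar size, a 1.4-fold lower number from compound 3 to compound 4 (0.16 log units; within the scatter), because compound 3 starts from 144000 nM. Compound 4 is therefore estimated at 100000 nM, with a likely range from 50000 nM to 250000 nM.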

Compound 4, half-maximal inhibitory concentration: 218000 nM
Beside the measured number, compound 4's estimate is 2.2-fold (0.34 log units) below it, within the range that was stated.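

In this assay, the change from 3-(trifluoromethyl)phenoxy to phenoxy gave a 1.5-fold higher number from compound 3 to compound 4 (0.18 log units; within the scatter). Set beside the earlier step, this one cannot be told apart from it: the same change on two cores in this assay, a 1.6-fold lower number (0.21 log units; within the scatter) from compound 1 to compound 2 and a 1.5-fold higher number (0.18 log units; within the scatter) from compound 3 to compound 4, 2.5-fold (0.39 log units) apart, within the scatter of two such steps. On both cores, then, the assay separates neither step from no change at all, and the two steps do not separate from each other, which shows no measurable difference in how this change carries from one core to the other; it does not show that the change is without effect or that it would read alike on a further core, and these two steps, each small and taken from a different place on the ring and a different core, cannot settle how far a step on one core predicts a step on another.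

The compounds shown leave open whether a different group in that place on the phenoxy ring, such as a chlorine, a methoxy group or a nitrile, would give a step beyond the scatter on either core. They also leave open whether a longer chain carrying the terminal amine would alter the size of the step from trifluoromethyl to hydrogen.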